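Methyl for Chloro: Expected Effect on Cell Toxicity

A few compounds are considered here, and "the series" means these few. Any claim that something is new, unique, unknown or untested is made for them only; others in the source may bear on it.

Two compounds sharing one core were tested in an ADME assay on HEp-2 cells (Homo sapiens) for cytotoxicity, read by MTT assay, with a stated time of 3 days; on this read-out higher numbers stand for lower toxicity in this test and lower numbers for higher toxicity in this test. Compound 1 `CC[C@H](CCn1cncn1)c1ccc(C)cc1` gives 75.2 ug/mL. Compound 2 `CCCC[C@H](CCn1cncn1)c1ccc(Cl)cc1` gives 20.2 ug/mL, the lowest of the two numbers; the number for compound 1 is higher by more than the usual scatter. Compound 3 `CCCC[C@H](CCn1cncn1)c1ccc(C)cc1` is not yet measured. It differs from compound 2 by methyl in place of chloro on an aromatic carbon. Going by the values given here, compound 1 also carries a methyl at that place, but its chain differs as well, so no single pair shows the size of this change alone. A small rise in the number, or none beyond the scatter, is expected. Compound 3 is estimated at 30 ug/mL, within 12 ug/mL to 75 ug/mL, an expected step of a 1.5-fold higher number from compound 2 to compound 3 (0.17 log units; within the scatter).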

Compound 3, half-maximal cytotoxic concentration: 23.7 ug/mL
Compound 3: middle estimate off by 1.3-fold (0.10 log units), on the high side, within the range that was stated.
By their numbers in this assay, from the lowest: compounds 2 and 3 (each within the scatter of the next); then compound 1.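

In this assay, methyl in place of chloro on the aromatic carbon gives a 1.2-fold higher number from compound 2 to compound 3 (0.07 log units; within the scatter), so this swap leaves the cell toxicity reading effectively unchanged. The chain matters more: ethyl in place of hydrogen on a saturated chain carbon gives a 3.2-fold lower number from compound 1 to compound 3 (0.50 log units; beyond the scatter), which is beyond the usual scatter. Nothing available explains the cause of either step. Going by these compounds, whether an amine or a carboxylic acid on that aromatic carbon would shift the number remains open. So does the effect of a longer chain.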